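The source may hold more compounds than are shown below. What is called first, only, known or untested is meant among the compounds shown, and "the series" means these compounds.

Compound 2 `O=C(O)c1cn(Cc2ccc(-c3ccccc3)cc2)c2cc(N3CC4CNCC4C3)c(F)cc2c1=O` has the lowest of the three numbers in an assay on isolated protein for inhibition of DNA topoisomerase 1 (Homo sapiens), with a stated time of 15 min; a lower number here means a stronger inhibitor, a higher number a weaker inhibitor: compound 2 gives 33300 nM. Going by the values given here, compound 3 `COc1c(N2CC[C@@H](CN)C2)c(F)cc2c(=O)c(C(=O)NO)cn(Cc3ccc(-c4ccccc4)cc3)c12` gives 35900 nM in this assay, within the scatter of compound 2, while compound 1 `O=C(O)c1cn(Cc2ccc(-n3cccn3)cc2)c2cc(N3CC4CNCC4C3)c(F)cc2c1=O` gives 173000 nM in this assay, and the only measured step, a 5.2-fold lower number from compound 1 to compound 2 (0.72 log units; beyond the scatter), lies beyond the scatter. Compound 4 `NCCNc1cc2c(cc1F)c(=O)c(C(=O)O)cn2Cc1ccc(-c2ccccc2)cc1` differs from compound 2 at the aromatic carbon ortho to the fluoro group: a group of 4 heavy atoms (2 carbon, 2 nitrogen; no ring) in place of a group of 8 heavy atoms (6 carbon, 2 nitrogen; 2 five-membered non-aromatic rings with 1 hetero atom each), on an aromatic carbon. Among the compounds with values here, no measured step touches this position, so the data give no direction; both groups contain nitrogen, and a small step either way, or none beyond the scatter, is plausible. Compound 4 is therefore expected to give about 60000 nM in this assay, with a range of 15000 nM to 250000 nM. That amounts to an expected step of a 1.8-fold higher number from compound 2 to compound 4 (0.26 log units; within the scatter).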

Compound 4, half-maximal inhibitory concentration: 72800 nM
Estimate against measurement, compound 4: 1.2-fold (0.08 log units) below, and the stated range covers the measured number.
By their numbers in this assay, from the lowest: compounds 2 and 3 (each within the scatter of the next); then compound 4; then compound 1.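

Going by these compounds alone, the change on the aromatic carbon ortho to a fluoro group gives the first measured step at this position: with (2-aminoethyl)amino in place of the group with 2 five-membered non-aromatic rings, this assay shows a 2.2-fold higher number from compound 2 to compound 4 (0.34 log units; beyond the scatter). The number therefore responds to this position, although the step is modest. No available evidence bears on what lies behind this step.

The compounds shown leave open how a piperazine or a longer chain such as (3-aminopropyl)amino would read at this carbon. They also leave open whether the step would hold with another group in place of the phenyl.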